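The source may hold more compounds than are shown below. What is called first, only, known or untested is meant among the compounds shown, and "the series" means these compounds.

In a functional assay on HeLa cells (Homo sapiens) for cytotoxicity, read by MTT assay, with a stated time of 48 h (a higher number here means a weaker inhibitor, a lower number a stronger inhibitor), the measured compounds are:
compound 1 `CC(C)(C)c1ccc(OC(=O)c2cn(-c3ccccc3)nc2-c2ccncc2)cc1`: 35400 nM
compound 2 `O=C(Oc1ccc2ccccc2c1)c1cn(-c2ccccc2)nc1-c1ccncc1`: > 100000 nM, which is a limit of the assay and not a number.

Compound 2 therefore stands only at the limit in this assay. For the measured compounds named here, the one measured step, an at least 2.8-fold higher number from compound 1 to compound 2 (0.45 log units; beyond the scatter), shows that the move from one ester group to the other already pushed the value up to the limit, where (the limit of > 100000 nM in this assay, at which 1 of the 2 values shown sits).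

Compound 3 `O=C(O)c1cn(-c2ccccc2)nc1-c1ccncc1` is the free acid: hydrogen in place of naphthalen-2-yl on an oxygen next to a carbonyl group. Going by the values given here, no measured step covers the loss of the whole ester group, so the step from compound 1 to compound 2 bears on it only indirectly. Compound 2 sits at the limit, and a weaker number cannot be read beyond it; the expectation is therefore that compound 3 also stays at the limit, with an expected step that the limit leaves unreadable from compound 2 to compound 3 that is not beyond the scatter. The estimate for compound 3 in this assay is 120000 nM, in the range 40000 nM to 400000 nM.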

Compound 3, half-maximal inhibitory concentration: > 100000 nM
Compound 3: no number, only a limit; the forecaster's own chance of this, stated with the estimate: 75%; the middle value does not contradict the limit.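

In this assay compound 3, the free acid, gives > 100000 nM, which is a limit of the assay and not a number. Hydrogen in place of 4-(tert-butyl)phenyl on an oxygen next to a carbonyl group removes the whole ester group and gives an at least 2.8-fold higher number from compound 1 to compound 3 (0.45 log units; beyond the scatter), so of the three compounds only compound 1 keeps a readable value. The step from compound 2 to compound 3 cannot be read, because both compounds sit at a limit: the limit of > 100000 nM in this assay, at which 2 of the 3 values shown sit.

The compounds shown leave open how far past the limit compound 2 and compound 3 lie, and so whether the naphthalen-2-yl ester and the free acid truly differ. They also leave open how an unsubstituted phenyl ester or an amide at this place would compare with compound 1.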